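Working notes: microsomal stability across three amine variants

The source may hold more compounds than are shown below. What is called first, only, known or untested is meant among the compounds shown, and "the series" means these compounds.

Measured so far:
compound 1 `NCCCCN(C[C@H]1Cc2nccnc2CN1)[C@H]1CCCc2cccnc21`: 50%
compound 2 `CN(C[C@@H]1Cc2ncccc2CN1)[C@H]1CCCc2cccnc21`: 1%
compound 3 `NC/C=C/CN(C[C@H]1Cc2ncccc2CN1)[C@H]1CCCc2cccnc21`: 11%

In an ADME assay on microsomes from liver (Rattus norvegicus) for metabolic stability, using NADPH, with a stated time of 10 min (on this read-out higher numbers stand for a more stable compound and lower numbers for a less stable compound), compound 1 gives 50%, compound 2 gives 1% and compound 3 gives 11%. Compound 3 stands second highest of the three; its number and that of compound 2 lie within the scatter of each other, whereas compound 1 lies beyond the scatter, on the higher side.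

Compound 4 `CN(CCCCN(C[C@H]1Cc2ncccc2CN1)[C@H]1CCCc2cccnc21)C1CCOCC1` is not yet measured. It differs from compound 3 in one place: a group of 11 heavy atoms (9 carbon, 1 nitrogen, 1 oxygen; one six-membered non-aromatic ring with 1 hetero atom) in place of a group of 4 heavy atoms (3 carbon, 1 nitrogen; no ring), on a saturated chain carbon bound to an amine nitrogen. For the measured compounds named here, no measured pair shows a change of this kind, so the expectation rests on little. The step of a number 4 percentage points higher from compound 3 to compound 4 (within the scatter) is expected to be small, not clearly beyond the scatter in either direction. Compound 4 is therefore estimated to give 15%, with a range from 2% to 45%.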

Compound 4, percent of the compound remaining: 64%
For compound 4 the middle estimate is 49 percentage points below the measured one, outside the stated range (above it).
By their numbers in this assay, from the lowest: compounds 2 and 3 (each within the scatter of the next); then compound 1; then compound 4.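

In this assay, for the compounds shown here, the exchange on a saturated chain carbon bound to an amine nitrogen gives a number 53 percentage points higher from compound 3 to compound 4 (beyond the scatter) and is the first one-place comparison. This position can therefore carry a large change in this read-out when the six-membered non-aromatic ring with 1 hetero atom enters in place of 3-aminoprop-1-en-1-yl. No measurement at hand bears on the reason for this step.

The ring, the double bond and the hydrogen-bond donor all change together, so the step cannot be assigned to any one of them. On these data alone, whether a cyclohexyl group, with carbon in place of the ring oxygen, would give a similar number remains open.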